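The compounds below may be only part of what the source reports. "The series", "measured", "known", "first", "only" and "open" are said of these compounds alone.

In a functional assay on A549 cells (Homo sapiens) for inhibition, read by MTT assay, with a stated time of 72 h (on this read-out higher numbers stand for weaker inhibition and lower numbers for stronger inhibition), three compounds sharing one core give closely spaced values: compound 1 (`Clc1ccc(-c2nnc(SCCCN3CCN(c4nc5ccccc5o4)CC3)o2)cc1`) gives 127000 nM, compound 2 (`Oc1ccc(-c2nnc(SCCCN3CCN(c4nc5ccccc5o4)CC3)o2)cc1`) gives 181000 nM and compound 3 (`c1ccc(-c2nnc(SCCCN3CCN(c4nc5ccccc5o4)CC3)o2)cc1`) gives 108000 nM. Compound 2 therefore stands level with the other two, as shown by a 1.4-fold higher number from compound 1 to compound 2 (0.15 log units; within the scatter) and a 1.7-fold lower number from compound 2 to compound 3 (0.22 log units; within the scatter). The remaining step, a 1.2-fold lower number from compound 1 to compound 3 (0.07 log units; within the scatter), is equally small.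

Compound 4 (`Oc1ccc(-c2nnc(SCCCN3CCN(c4nc5ccccc5s4)CC3)o2)cc1`) keeps the hydroxy group of compound 2 and changes the group on an amine nitrogen in a ring: 1,3-benzothiazol-2-yl in place of 1,3-benzoxazol-2-yl on an amine nitrogen in a ring. Among the measured compounds shown here, none of the measured steps touches that group. All three exchange chloro, hydroxy and hydrogen on an aromatic carbon, so they bear on this change only indirectly, showing that the values in this assay have so far stayed within the scatter. The data hold no direct evidence for the new group, so no step beyond the scatter is expected, and no direction is favoured with confidence. The expected step is a 1.2-fold lower number from compound 2 to compound 4 (0.08 log units; within the scatter). For compound 4 the estimated value is 150000 nM, with an expected range from 70000 nM to 320000 nM.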

Compound 4, half-maximal inhibitory concentration: 62100 nM
Estimate against measurement, compound 4: 2.4-fold (0.38 log units) above; the whole stated range lies above it.
By their numbers in this assay, from the lowest: compounds 4, 3, 1 and 2 (each within the scatter of the next, the first and the last beyond it).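

In this assay, among the compounds shown here, 1,3-benzothiazol-2-yl in place of 1,3-benzoxazol-2-yl on the amine nitrogen in a ring gives a 2.9-fold lower number from compound 2 to compound 4 (0.46 log units; beyond the scatter) and is the first step here beyond the scatter, whereas all the exchanges on the aromatic carbon stayed within it. The two groups have the same heavy-atom count and the same hydrogen-bond donor and acceptor counts, differing by sulfur in place of oxygen, and that single exchange at this position is enough for a modest step. Nothing available explains the step.

The compounds shown leave open whether the step holds when chloro or hydrogen replaces the hydroxy group of compound 4. They also leave open how a plain phenyl group or a benzimidazol-2-yl group would behave on the same nitrogen.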